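Methyl for Isopropyl on the Amide Nitrogen of Compound 3

The source may report more compounds than this note shows. Statements on the series, on what has been measured and on what is new or still open speak of the compounds shown alone.

Compound 1 `COc1ccc([N+](=O)[O-])cc1CSc1nc2cc(NC(=O)OC(C)(C)C)ccc2n1C(C)C`: 710 nM
Compound 2 `COc1ccc([N+](=O)[O-])cc1CSc1nc2cc(NC(=O)C3CCC3)ccc2n1C(C)C`: 630 nM
Compound 3 `COc1ccc([N+](=O)[O-])cc1CSc1nc2cc(NC(=O)NC(C)C)ccc2n1C(C)C`: 280 nM

In an assay on isolated protein for inhibition of Gonadotropin-releasing hormone receptor (Rattus norvegicus) (a lower number here means a stronger inhibitor, a higher number a weaker inhibitor), compound 3 gives the lowest of the three numbers; the nearest is a 2.3-fold lower number from compound 2 to compound 3 (0.35 log units; beyond the scatter) and the furthest a 2.5-fold lower number from compound 1 to compound 3 (0.40 log units; beyond the scatter), both beyond the scatter, while a 1.1-fold lower number from compound 1 to compound 2 (0.05 log units; within the scatter) lies within it. Compound 4 `CNC(=O)Nc1ccc2c(c1)nc(SCc1cc([N+](=O)[O-])ccc1OC)n2C(C)C` differs from compound 3 by methyl in place of isopropyl on an amide-type nitrogen. Going by the values given here, no measured step alters this amide-type nitrogen; the three measured steps all replace the group on the carbonyl carbon, so they bear on the change only loosely. The isopropylamino group is the one that brought the modest gain in a 2.5-fold lower number from compound 1 to compound 3 (0.40 log units; beyond the scatter), and shortening it to methyl is expected to cost a little, as a 1.5-fold higher number from compound 3 to compound 4 (0.18 log units; within the scatter). Compound 4 is therefore estimated at 420 nM, in the range 150 nM to 1100 nM.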

Compound 4, half-maximal inhibitory concentration: > 10000 nM
Compound 4: only a limit was reported (the forecaster's own chance of this, stated with the estimate: 0%); middle value at least 23-fold (1.37 log units) away from the limit.
By their numbers in this assay, from the lowest: compound 3; then compounds 2 and 1 (each within the scatter of the next). At a limit, above all of these: compound 4.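

On the amide-type nitrogen, a change of only methyl in place of isopropyl gives an at least 35-fold higher number from compound 3 to compound 4 (1.55 log units; beyond the scatter), far larger than any step seen among the groups on the carbonyl carbon. In this assay, compound 4 gives only a limit, not a number: the limit of > 10000 nM in this assay, at which 1 of the 4 values shown sits. Methylamino also falls behind cyclobutyl, with an at least 15-fold higher number from compound 2 to compound 4 (1.20 log units; beyond the scatter), and behind tert-butoxy, with an at least 14-fold higher number from compound 1 to compound 4 (1.14 log units; beyond the scatter).

Going by these compounds, it remains open whether ethylamino would recover the value of compound 3. On these data alone, it is also open whether tert-butylamino or cyclohexylamino would give a lower number still.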